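The source may hold more compounds than are shown below. What is called first, only, known or untested is meant among the compounds shown, and "the series" means these compounds.

Measured compounds in a functional assay on DU-145 cells (Homo sapiens) for cytotoxicity, read by sulforhodamine B assay, with a stated time of 48 h; a higher number here means that more compound is tolerated, a lower number that less compound is tolerated:
compound 1, `COc1ccc(CN2CCN(c3nc(Nc4ccc(C#N)c(C(F)(F)F)c4)nc(Oc4ccnc5ccccc45)n3)CC2)c(OC)c1OC`: > 100000 nM
compound 2, `N#Cc1ccc(Nc2nc(Oc3ccnc4ccccc34)nc(N3CCN(c4ncccn4)CC3)n2)cc1C(F)(F)F`: > 100000 nM
compound 3, `CC(=O)N1CCN(c2nc(Nc3ccc(C#N)c(C(F)(F)F)c3)nc(Oc3ccnc4ccccc34)n2)CC1`: > 100000 nM

Of the compounds shown here, three built on the same core have been tested in this assay, and each of them returns a limit of the assay rather than a number. Compound 1 gives > 100000 nM, which is a limit. Compound 2 gives > 100000 nM, also a limit. Compound 3 gives > 100000 nM, again a limit. Compound 1 therefore stands at the limit of > 100000 nM in this assay, at which 3 of the 3 values shown sit, and the data give no number that would place it above or below the other two.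

Among the measured compounds shown here, only one pair differs in a single place: the move from compound 2 to compound 3, in which an acetyl replaces a pyrimidin-2-yl on an amine nitrogen in a ring, gives a step that the two limits leave unreadable from compound 2 to compound 3.

Compound 4 `N#Cc1ccc(Nc2nc(Oc3ccnc4ccccc34)nc(N3CCN(Cc4ccccc4)CC3)n2)cc1C(F)(F)F` has not yet been measured. It differs from compound 1 by phenyl in place of 2,3,4-trimethoxyphenyl on a saturated chain carbon bound to an amine nitrogen in a ring; the 2,3,4-trimethoxyphenyl that leaves carries three hydrogen-bond acceptors, the phenyl that enters carries none. For the measured compounds named here, no measured step involves this change, and the one measured step is unreadable, so the data give no basis for expecting movement in either direction beyond the scatter. Since compound 1 gives > 100000 nM, compound 4 is expected to sit at the limit as well, with an estimated 100000 nM and a range of 30000 nM to 300000 nM. The expected step from compound 1 to compound 4 is a number no higher from compound 1 to compound 4 (the limit leaves the size open).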

Compound 4, concentration lethal to 50% of the cells: > 100000 nM
Compound 4: no number, only a limit; the forecaster's own chance of this, stated with the estimate: 80%; the middle value lies on the limit itself.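

Compound 4 gives > 100000 nM, which is a limit and not a number. The steps to compound 4 from compound 1, compound 2 and compound 3 therefore cannot be read, and all four compounds share one limit: the limit of > 100000 nM in this assay, at which 4 of the 4 values shown sit.

The compounds shown leave open whether any group on the amine nitrogen in a ring changes the lethal concentration at all.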